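Benzyloxycarbonyl for Phenyl on a Weakly Active Benzamide

The source may report more compounds than this note shows. Statements on the series, on what has been measured and on what is new or still open speak of the compounds shown alone.

compound 1: `Nc1cc(-c2ccccc2)ccc1NC(=O)c1ccc(CNc2nccc(-c3cccnc3)n2)cc1` — > 20000 nM
compound 2: `Nc1ccccc1NC(=O)c1ccc(CNC2=NC(=O)C(Cc3ccccc3)N2)cc1` — 13000 nM
compound 3: `Nc1ccccc1NC(=O)c1ccc(CSC2=N[C@@H](Cc3ccccc3)CS2)cc1` — > 20000 nM

Of the compounds shown here, three have been tested in an assay for inhibition of histone deacetylase 8 (Homo sapiens), read by fluorescence, with stated times of 15 min and 60 min; a lower number here means a stronger inhibitor, a higher number a weaker inhibitor. Compound 1 gives no number in this assay, only the limit > 20000 nM. Compound 3 also gives only the limit, > 20000 nM. Compound 2 alone gives a number, 13000 nM. This is summarised by the limit of > 20000 nM in this assay, at which 2 of the 3 values shown sit. Going by the values given here, compound 1 therefore stands among the compounds for which only a limit is known; no step between measured compounds that differ in one place is available, so no measured change in this assay can be used as a guide.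

Compound 4, `Nc1cc(C(=O)OCc2ccccc2)ccc1NC(=O)c1ccc(CNc2nccc(-c3cccnc3)n2)cc1`, differs from compound 1 by benzyloxycarbonyl in place of phenyl on an aromatic carbon. Among the compounds with values here, with no measured step to rest on, and with compound 1 at the limit, the change is expected to give no step beyond the usual scatter, and compound 4 is expected to remain close to the limit of the assay. The expected step of a number no higher from compound 1 to compound 4 (the limit leaves the size open) is therefore essentially none. For compound 4 the estimated value in this assay is 20000 nM, expected to fall between 6000 nM and 60000 nM.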

Compound 4, half-maximal inhibitory concentration: > 20000 nM
Compound 4: a limit, no number; the forecaster's own chance of this, stated with the estimate: 60%; the middle value sits exactly at the limit.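

Compound 4 gives only a limit in this assay, > 20000 nM, and since compound 1 is also known only by a limit, the step between the two cannot be read. The compounds shown leave open whether benzyloxycarbonyl in place of phenyl on this aromatic carbon changes inhibition at all.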